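Carbamoyl to 1H-tetrazol-5-yl at the chain end

A few compounds are considered here, and "the series" means these few. Any claim that something is new, unique, unknown or untested is made for them only; others in the source may bear on it.

Measured so far:
compound 1, `CCc1cc(C(C)=O)c(O)cc1OCCCC(C)(C)C(=O)O`: 12%
compound 2, `CCc1cc(C(C)=O)c(O)cc1OCCCCCC(C)(C)C(=O)O`: 20%
compound 3, `CCc1cc(C(C)=O)c(O)cc1OCCCC(C)(C)C(N)=O`: 16%

In an assay on isolated protein for binding affinity to leukotriene B4 receptor (Homo sapiens), tested at 0.1 uM (on this read-out lower numbers stand for less inhibition and higher numbers for more inhibition at the one concentration tested (going by the name of the read-out)), compound 3 stands second highest of the three numbers. Its nearest neighbour is compound 1, reached by a number 4 percentage points higher from compound 1 to compound 3 (within the scatter); its furthest is compound 2, from which a number 4 percentage points lower from compound 2 to compound 3 (within the scatter). All three numbers sit within the scatter of one another, so no order among them can be read.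

Compound 4, `CCc1cc(C(C)=O)c(O)cc1OCCCC(C)(C)c1nnn[nH]1`, differs from compound 3 in one place: 1H-tetrazol-5-yl in place of carbamoyl on a saturated chain carbon bound to three saturated chain carbons.

Going by the values given here, two measured steps touch the same region of the molecule. The step of a number 4 percentage points higher from compound 1 to compound 3 (within the scatter) changes only the group on the carbonyl carbon and stays within the scatter; the step of a number 8 percentage points higher from compound 1 to compound 2 (within the scatter) lengthens the chain that carries the acid and also stays within the scatter. Among the compounds with values here, neither step involves a ring of any kind, so the tetrazole entry has no direct precedent here. The available steps give no ground to expect a change beyond the scatter; the estimated step of a number 6 percentage points higher from compound 3 to compound 4 (within the scatter) is expected to be small.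

Compound 4 is therefore expected to give 22%, with a range from 6% to 42%.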

Compound 4, a percentage reported as inhibition, at one concentration (the size of the read-out at that concentration, not a potency): 28%
The estimate for compound 4 lay 6 percentage points below the measured number, within the range that was stated.
By their numbers in this assay, from the lowest: compounds 1, 3, 2 and 4 (each within the scatter of the next, the first and the last beyond it).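

In this assay, going by these compounds alone, 1H-tetrazol-5-yl at the saturated chain carbon bound to three saturated chain carbons gives the first steps that lie beyond the scatter (a number 12 percentage points higher from compound 3 to compound 4 (beyond the scatter)) and (a number 16 percentage points higher from compound 1 to compound 4 (beyond the scatter)). The read-out at this chain end therefore does respond to the group placed there, though only modestly, while the tetrazole cannot be separated from the longer acid of compound 2 (a number 8 percentage points higher from compound 2 to compound 4 (within the scatter)). No measurement on hand explains these steps.

As far as these compounds go, it remains open whether 1H-tetrazol-5-yl on the longer chain of compound 2 would go further than either change alone. Also open, from the compounds shown here alone, is how a sulfonic acid or a methyl group on a tetrazole nitrogen would read at this chain end.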